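The source may hold more compounds than are shown below. What is called first, only, known or untested is meant among the compounds shown, and "the series" means these compounds.

Measured in a physicochemical assay for solubility, read by spectrophotometry, measured as kinetic solubility, at pH 8, tested at 500 uM; on this read-out higher numbers stand for higher solubility and lower numbers for lower solubility:
- compound 1 `CN(C)C(=O)c1ccncc1Nc1cc(-c2ccc3ccn(C)c3c2)c2nccnc2c1`: 175 ug/mL
- compound 2 `CC(=O)N1CCC(NC(=O)c2ccncc2Nc2cc(-c3ccc4ccn(C)c4c3)c3nccnc3c2)CC1`: 213 ug/mL

Among the measured compounds shown here, compound 2 cannot be separated from compound 1 on these numbers: the only measured step is a 1.2-fold higher number from compound 1 to compound 2 (0.09 log units; within the scatter). Next in line is compound 3 `Cn1ccc2ccc(-c3cc(Nc4cnccc4C(=O)NC4CCNC(=O)C4)cc4nccnc34)cc21`, which differs from compound 2 as follows: 2-oxopiperidin-4-yl in place of 1-acetylpiperidin-4-yl on an amide-type nitrogen. This exchange falls on the same amide side chain that changed in the measured step. For the measured compounds named here, that single step is the only evidence bearing on it, and it stayed within the scatter. Going by the values given here, no measured compound carries the 2-oxopiperidin-4-yl group, so the support is thin. No change beyond the scatter is therefore expected in this assay, and the estimated step is a 1.2-fold lower number from compound 2 to compound 3 (0.07 log units; within the scatter). Compound 3 is expected at 180 ug/mL, with an estimated range of 90 ug/mL to 260 ug/mL.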

Compound 3, solubility: 242 ug/mL
Estimate against measurement, compound 3: 1.3-fold (0.13 log units) below; low and high end bracket the measured number.
By their numbers in this assay, from the lowest: compounds 1, 2 and 3 (each within the scatter of the next).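

In this assay, putting 2-oxopiperidin-4-yl in place of 1-acetylpiperidin-4-yl on the amide-type nitrogen brings in 1 hydrogen-bond donor where the leaving group has 0, and the result is a 1.1-fold higher number from compound 2 to compound 3 (0.06 log units; within the scatter). Replacing dimethylamino on the carbonyl carbon with (2-oxopiperidin-4-yl)amino gives a 1.4-fold higher number from compound 1 to compound 3 (0.14 log units; within the scatter), so all three side chains shown now stand within the scatter of one another, including the pair that differ by this donor. No supporting data bear on why these values sit together.

Going by these compounds, it remains open whether an open-chain amine or a carboxylic acid on this amide nitrogen would move the number beyond the scatter. The same question stands for any change to the shared core, which is identical in all three compounds.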